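Methylation of a Ring Hydroxyl on Two Related Cores

The source may report more compounds than this note shows. Statements on the series, on what has been measured and on what is new or still open speak of the compounds shown alone.

Compound 1 `COc1cc2nccc(O)c2c(O)c1OC` and compound 2 `COc1cc2nccc(O)c2c(OC)c1OC` share one core; compound 3 `Cc1ccc(O)c2c(O)ccnc12` and compound 4 `COc1ccc(C)c2nccc(O)c12` share another. The difference between the two cores is not broken down here. Within each pair the change is the same: from compound 1 to compound 2 it reads (methyl in place of hydrogen on an oxygen on an aromatic ring), and from compound 3 to compound 4 it reads (methyl in place of hydrogen on an oxygen on an aromatic ring).

In a functional assay on L1210 cells (Mus musculus) for antiproliferative activity (on this read-out lower numbers stand for stronger inhibition and higher numbers for weaker inhibition), compound 1 gives only a limit, > 40000 nM. Compound 2 likewise gives only a limit in this assay, > 40000 nM. Compound 3 too gives only a limit in this assay, > 40000 nM. The step that the two limits leave unreadable from compound 1 to compound 2 therefore cannot be read, since both ends sit at the limit of > 40000 nM in this assay, at which 3 of the 3 values shown sit.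

For compound 4 the same change is applied to compound 3, whose value is itself a limit, so the expected step that the limit leaves unreadable from compound 3 to compound 4 rests only on the unreadable earlier step and on the limit shown for compound 3. Compound 4 is accordingly expected to give about 50000 nM in this assay, between 15000 nM and 200000 nM, most likely again as a limit rather than a number.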

Compound 4, half-maximal inhibitory concentration: > 40000 nM
Compound 4: only a limit was reported (the forecaster's own chance of this, stated with the estimate: 85%); the middle value does not contradict the limit.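

No size can be read for the step from compound 3 to compound 4, since compound 3 and compound 4 both give only a limit in this assay: the limit of > 40000 nM in this assay, at which 4 of the 4 values shown sit.

The compounds shown leave open whether replacing hydroxy with methoxy changes antiproliferative activity on either core, and how strong any of the four compounds actually is.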